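This account rests on a few compounds, and the source may have more. Where it says the series, first, only, none or still open, it means among the compounds named here.

Notes on the series. Compound 1 `Cc1cccc(CN2CCC(NC(=O)c3cccc4ccccc34)CC2)c1` and compound 2 `Cc1ccc(CN2CCC(NC(=O)c3cccc4ccccc34)CC2)cc1` share one core. In an assay on isolated protein for displacement of a labelled ligand from D(4) dopamine receptor (Homo sapiens) (a higher number here means a weaker inhibitor, a lower number a stronger inhibitor), compound 1 gives 77 nM and compound 2 gives 69 nM. The step between them, a 1.1-fold lower number from compound 1 to compound 2 (0.05 log units; within the scatter), comes from 4-methylphenyl in place of 3-methylphenyl on a saturated chain carbon bound to an amine nitrogen in a ring. Compound 3 `Cc1cccc(CN2CCC(NC(=O)c3ccc4ccccc4c3)CC2)c1` carries a different core; how the core of compound 3 differs from the core of compound 1 is not broken down here. In this assay compound 3 gives 11 nM, the lowest of the three numbers. Compound 4 `Cc1ccc(CN2CCC(NC(=O)c3ccc4ccccc4c3)CC2)cc1` is not yet measured; it differs from compound 3 by 4-methylphenyl in place of 3-methylphenyl on a saturated chain carbon bound to an amine nitrogen in a ring, the same change as from compound 1 to compound 2, at the same place. The step expected from compound 3 to compound 4 in this assay is a 1.1-fold lower number from compound 3 to compound 4 (0.04 log units; within the scatter), resting on the earlier step of a 1.1-fold lower number from compound 1 to compound 2 (0.05 log units; within the scatter). Compound 4 is thus estimated at 10 nM in this assay, likely between 4 nM and 25 nM.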

Compound 4, inhibition constant: 21 nM
Estimate against measurement, compound 4: 2.1-fold (0.32 log units) below; the range from low to high includes it.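

In this assay, 4-methylphenyl in place of 3-methylphenyl on the core of compound 3 gives a 1.9-fold higher number from compound 3 to compound 4 (0.28 log units; within the scatter). Set beside the same change on the core of compound 1, the two steps cannot be told apart: the same change on two cores in this assay, a 1.1-fold lower number (0.05 log units; within the scatter) from compound 1 to compound 2 and a 1.9-fold higher number (0.28 log units; within the scatter) from compound 3 to compound 4, 2.1-fold (0.33 log units) apart, within the scatter of two such steps On these two cores, then, the change carries over with no step beyond the scatter, but two small steps do not show that it would stay small on any other core.

The compounds shown leave open how the series responds to a group other than methyl on the phenyl ring, such as methoxy or chloro. Also open, going by these compounds, is the effect of a longer chain in place of the single carbon that links the phenyl ring to the ring nitrogen.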